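The source may hold more compounds than are shown below. What is called first, only, known or untested is meant among the compounds shown, and "the series" means these compounds.

Measured so far in an ADME assay on the whole organism (Mus musculus, strain CD-1) for pharmacokinetics, with a stated time of 6 h, at a dose of 10 mg/kg by the oral route; on this read-out lower numbers stand for lower exposure and higher numbers for higher exposure at the dose given:
Compound 1 `Cc1c(C(=O)N2CCC[C@@H](N)C2)nc(-c2ccc(C#N)c(F)c2)n1-c1ccc2nn(C)cc2c1`: 25 ng.h/mL
Compound 2 `Cc1c(C(=O)N2CCC[C@@H](N)C2)nc(-c2ccc(C#N)c(F)c2)n1-c1ccc2c(cnn2C)c1`: 106 ng.h/mL

Compound 2 holds the higher number of the two. Compound 3 `Cc1c(C(=O)N2CCC[C@@H](N)C2)nc(-c2ccc(C#N)c(F)c2)n1-c1ccc2nn(C)c(Cl)c2c1` differs from it as follows: 3-chloro-2-methyl-2H-indazol-5-yl in place of 1-methyl-1H-indazol-5-yl on an aromatic nitrogen. Within the data shown here, only one measured step bears on this: a 4.2-fold higher number from compound 1 to compound 2 (0.63 log units; beyond the scatter), with 1-methyl-1H-indazol-5-yl in place of 2-methyl-2H-indazol-5-yl. The entering group returns to the 2-methyl-2H-indazol-5-yl form of compound 1, which gave 25 ng.h/mL, but now carries chlorine, and no measurement shows what chlorine does here. A partial fall is therefore expected, as a 2.4-fold lower number from compound 2 to compound 3 (0.37 log units; beyond the scatter). For compound 3 the estimated value is 45 ng.h/mL, within a range of 12 ng.h/mL to 170 ng.h/mL.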

Compound 3, area under the concentration-time curve: 100 ng.h/mL
The estimate for compound 3 lay 2.2-fold (0.35 log units) below the measured number; the measured number falls inside the stated range.
By their numbers in this assay, from the lowest: compound 1; then compounds 3 and 2 (each within the scatter of the next).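

In this assay, putting chloro on the 2-methyl-2H-indazol-5-yl group gives a 4.0-fold higher number from compound 1 to compound 3 (0.60 log units; beyond the scatter) and so lifts the low exposure of compound 1. Exchanging the 1-methyl-1H-indazol-5-yl group for 3-chloro-2-methyl-2H-indazol-5-yl gives a 1.1-fold lower number from compound 2 to compound 3 (0.03 log units; within the scatter) and so leaves the two groups indistinguishable on this read-out. Nothing measured here explains what chlorine does. From the compounds shown here alone, it remains open whether bromine or a methoxy group on the same ring carbon would give a similar gain. Going by these compounds, the effect of chloro on the 1-methyl-1H-indazol-5-yl group also remains open.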